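Naphthalenyl in place of bromophenyl in an SK-BR-3 series

A few compounds are considered here, and "the series" means these few. Any claim that something is new, unique, unknown or untested is made for them only; others in the source may bear on it.

Measured compounds:
compound 1 `COc1ccc(C(=O)Nc2ccc(N(C)S(C)(=O)=O)c(OCc3cc(Cl)ccc3Cl)c2)cc1OC` — 3730 nM
compound 2 `COc1ccc(OC)c(COc2cc(NC(=O)c3ccc(I)cc3)ccc2N(C)S(C)(=O)=O)c1` — 1.21 nM
compound 3 `COc1ccc(OC)c(COc2cc(NC(=O)c3ccc(Br)cc3)ccc2NS(C)(=O)=O)c1` — 9.58 nM

In a functional assay on SK-BR-3 cells (Homo sapiens) for antiproliferative activity, read by MTT assay, with a stated time of 48 h (a higher number here means a weaker inhibitor, a lower number a stronger inhibitor), compound 3 gives 9.58 nM, the second highest of the three numbers. Its nearest neighbour is compound 2 with 1.21 nM, a lower number by a margin beyond the scatter; the furthest is compound 1 with 3730 nM, a far higher number. No two of these compounds differ in only one place, so no single step is read directly from them.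

Compound 4 `COc1ccc(OC)c(COc2cc(NC(=O)c3ccc4ccccc4c3)ccc2NS(C)(=O)=O)c1` has not been measured. It differs from compound 3 in one place: naphthalen-2-yl in place of 4-bromophenyl on a carbonyl carbon. Among the measured compounds shown here, no measured pair shows this change, so the expectation rests on the range the series spans. The author expects a step from compound 3 to compound 4 of a 2.1-fold higher number from compound 3 to compound 4 (0.32 log units; beyond the scatter), most likely a modest rise in the number, though a step within the scatter would not surprise. Compound 4 is estimated at 20 nM, with a range from 4 nM to 120 nM.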

Compound 4, half-maximal inhibitory concentration: 13.3 nM
Beside the measured number, compound 4's estimate is 1.5-fold (0.18 log units) above it; low and high end bracket the measured number.
By their numbers in this assay, from the lowest: compound 2; then compounds 3 and 4 (each within the scatter of the next); then compound 1.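

Among the compounds shown here, the change from 4-bromophenyl to naphthalen-2-yl on a carbonyl carbon gives, in this assay, a 1.4-fold higher number from compound 3 to compound 4 (0.14 log units; within the scatter), the first comparison that differs in one place only. It shows that this position takes a group of 10 heavy atoms with 2 six-membered aromatic rings in place of one of 7 heavy atoms with a single ring, and that the bromine can be absent, with no step beyond the scatter. Nothing among the data offers an explanation for this result.

The compounds shown leave open how a plain phenyl, a pyridinyl or a cyclohexyl group would read on this carbonyl carbon. They also leave open whether naphthalen-2-yl would give a similar step on the core of compound 2.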